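Removing the methyl on the amide-type nitrogen

The compounds below may be only part of what the source reports. "The series", "measured", "known", "first", "only" and "open" are said of these compounds alone.

Measured in an ADME assay on the whole organism (Rattus norvegicus, strain Sprauge-Dawley) for pharmacokinetics (on this read-out higher numbers stand for higher oral bioavailability and lower numbers for lower oral bioavailability), so far:
compound 1 `COC(=O)N(C)c1c(N)nc(-n2nc(Cc3ccccc3F)c3cc(F)ccc32)nc1N` gives 22%
compound 2 `COC(=O)N(C)c1c(N)nc(-n2nc(Cc3c(F)ccc(F)c3F)c3ccccc32)nc1N` gives 68%
compound 3 `COC(=O)N(C)c1c(N)nc(-n2nc(Cc3c(F)ccc(F)c3F)c3cc(Cl)ccc32)nc1N` gives 51%

Compound 3 stands second highest of the three numbers, beyond the scatter below compound 2 and beyond the scatter above compound 1. Among the compounds with values here, the only single-point step measured is a number 17 percentage points lower from compound 2 to compound 3 (beyond the scatter), a chloro in place of hydrogen on an aromatic carbon; it does not touch the carbamate nitrogen. Compound 4 `COC(=O)Nc1c(N)nc(-n2nc(Cc3c(F)ccc(F)c3F)c3cc(Cl)ccc32)nc1N` differs from compound 3 by hydrogen in place of methyl on an amide-type nitrogen. Within the data shown here, no measured pair changes this nitrogen, so nothing here bears directly on the step; a change of the expected size a number 3 percentage points lower from compound 3 to compound 4 (within the scatter) is taken as none beyond the scatter. Compound 4 is therefore estimated at 48%, with a range of 25% to 70%.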

Compound 4, oral bioavailability: 37%
The estimate for compound 4 lay 11 percentage points above the measured number, within the range that was stated.
By their numbers in this assay, from the lowest: compound 1; then compound 4; then compound 3; then compound 2.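

In this assay, the amide-type nitrogen proves to be a position that responds to change: hydrogen in place of methyl gives a number 14 percentage points lower from compound 3 to compound 4 (beyond the scatter). The methyl therefore cannot be dropped here without a loss on this read-out, at least with the chloro group present. Nothing available gives a reason for this step.

From the compounds shown here alone, whether an ethyl group or a longer chain on this nitrogen would hold, raise or lower the number remains open. So does whether the same step would appear on compound 2, which lacks the chloro group.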